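The source may report more compounds than this note shows. Statements on the series, on what has been measured and on what is new or still open speak of the compounds shown alone.

Working notes on the series.

Compound 1 `CCCC(O)CC(=O)O[C@H](CC=C(C)C)C1=CC(=O)c2c(O)ccc(O)c2C1=O` is the reference point. Going by the values given here, in a functional assay on HeLa cells (Homo sapiens) for cytotoxicity, read by MTT assay (a higher number here means a weaker inhibitor, a lower number a stronger inhibitor), compound 1 gives 59300 nM, the second highest of the three numbers measured so far. Compound 2 `CCCCC(CC(=O)O[C@H](CC=C(C)C)C1=CC(=O)c2c(O)ccc(O)c2C1=O)OC(C)=O` gives 73500 nM and compound 3 `CC(C)=CC[C@@H](OC(=O)CC(O)c1ccccc1)C1=CC(=O)c2c(O)ccc(O)c2C1=O` gives 44500 nM. The three measured steps are all small: a 1.2-fold higher number from compound 1 to compound 2 (0.09 log units; within the scatter), a 1.3-fold lower number from compound 1 to compound 3 (0.12 log units; within the scatter) and a 1.7-fold lower number from compound 2 to compound 3 (0.22 log units; within the scatter). Each of these changes the side chain while keeping the (2-hydroxypentyl)carbonyl-type linkage to the oxygen on the saturated carbon in place, and none of them moves this assay beyond the scatter.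

Compound 4 `CCC(O)CO[C@H](CC=C(C)C)C1=CC(=O)c2c(O)ccc(O)c2C1=O` differs from compound 1 as follows: 2-hydroxybutyl in place of (2-hydroxypentyl)carbonyl on an oxygen on a saturated carbon. Among the compounds with values here, no measured step removes the carbonyl from this oxygen, so there is no direct precedent. Given that every side-chain variation recorded so far left this assay within the scatter, the expected step is a 1.0-fold lower number from compound 1 to compound 4 (0.00 log units; within the scatter), with no direction beyond the scatter. The estimate for compound 4 in this assay is 59000 nM, with a range from 25000 nM to 140000 nM.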

Compound 4, half-maximal inhibitory concentration: 28700 nM
Compound 4: middle estimate off by 2.1-fold (0.31 log units), on the high side; low and high end bracket the measured number.
By their numbers in this assay, from the lowest: compounds 4, 3, 1 and 2 (each within the scatter of the next, the first and the last beyond it).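

Going by these compounds alone, on an oxygen on a saturated carbon, 2-hydroxybutyl in place of (2-hydroxypentyl)carbonyl gives a 2.1-fold lower number from compound 1 to compound 4 (0.32 log units; beyond the scatter) in this assay, the only step from the reference compound that lies beyond the scatter. The carbonyl on this oxygen is therefore not needed to retain the activity of compound 1 in this pair, but the same change also takes the group from 8 heavy atoms to 5, so the two differences cannot be separated here. No available evidence bears on the cause of this modest step.

As far as these compounds go, it remains open whether the lower number follows the loss of the carbonyl or the shorter group, a question that a longer chain such as 2-hydroxypentyl on the same oxygen would address. From the compounds shown here alone, how a phenyl-bearing chain or an amine would behave on this oxygen also remains open.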